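The source may hold more compounds than are shown below. What is called first, only, known or untested is meant among the compounds shown, and "the series" means these compounds.

In a functional assay on MKN-74 cells (Homo sapiens) for antiproliferative activity, with a stated time of 24 h (on this read-out lower numbers stand for stronger inhibition and higher numbers for weaker inhibition), three close relatives of one shared core have been measured. Compound 1, `NC(=O)c1c(NC(=O)c2ccccc2Cl)sc2c1CCN(Cc1ccccc1Cl)C2`, gives 4430 nM. Compound 2, `NC(=O)c1c(NC(=O)c2ccccc2Cl)sc2c1CCN(Cc1c(Cl)cccc1Cl)C2`, gives 4740 nM. Compound 3, `NC(=O)c1c(NC(=O)c2ccccc2)sc2c1CCN(C(=S)Nc1ccccc1Cl)C2`, gives 11800 nM, the highest of the three numbers; its distance to compound 2 and to compound 1 lies beyond the scatter of repeated measurements.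

Compounds 2 and 1 differ in one place, (hydrogen in place of chloro on an aromatic carbon). That change produced a 1.1-fold lower number from compound 2 to compound 1 (0.03 log units; within the scatter), so the two values cannot be told apart. How the core of compound 3 differs from that of compound 2 is not broken down here.

Compound 4, `NC(=O)c1c(NC(=O)c2ccccc2)sc2c1CCN(C(=S)Nc1ccccc1)C2`, has not yet been measured in this assay. It differs from compound 3 by hydrogen in place of chloro on an aromatic carbon. Among the compounds with values here, this is the same kind of change as the one from compound 2 to compound 1, though the surroundings of the place differ: in the earlier pair the aromatic carbon was also meta to a chloro group, whereas in compound 3 it is only ortho to a large group.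

Because the earlier step of a 1.1-fold lower number from compound 2 to compound 1 (0.03 log units; within the scatter) stayed within the scatter, compound 3 to compound 4 is expected to give a step of about a 1.1-fold lower number from compound 3 to compound 4 (0.03 log units; within the scatter), again within the scatter. Compound 4 is therefore estimated to give 11000 nM in this assay, with a likely range from 5000 nM to 25000 nM.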

Compound 4, half-maximal inhibitory concentration: > 50000 nM
Compound 4: no number, only a limit (the forecaster's own chance of this, stated with the estimate: 8%); middle value at least 4.5-fold (0.65 log units) from the limit.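

In this assay compound 4 gives > 50000 nM and that is a limit of the assay, not a number. Replacing the chloro of the 2-chlorophenyl group with hydrogen gives an at least 4.2-fold higher number from compound 3 to compound 4 (0.62 log units; beyond the scatter) and so did not carry over with the same size from one core to the other: the same change on two cores in this assay, a 1.1-fold lower number (0.03 log units; within the scatter) from compound 2 to compound 1 and an at least 4.2-fold higher number (0.62 log units; beyond the scatter) from compound 3 to compound 4, at least 4.5-fold (0.65 log units) apart, beyond the scatter of two such steps. As far as these compounds go, in this series, then, the size of this change on one core cannot be read across to the other, but two pairs do not show which feature of the cores sets the gap, and the full size of the new step remains unknown since it ends in a limit.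

The compounds shown leave open whether the chloro itself matters on the core of compound 3, or whether a fluoro, a methyl or a methoxy group in its place would serve as well. They also leave open whether the same replacement would behave as it does here with a chloro on the benzoyl ring, which compound 1 and compound 2 carry and compound 3 and compound 4 lack.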